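Microsomal stability notes: compound 4 against compound 2

The compounds below may be only part of what the source reports. "The series", "measured", "known", "first", "only" and "open" are said of these compounds alone.

Measured so far:
compound 1 `O=C(NCc1ccc(S(=O)(=O)c2cc(F)cc(F)c2)cc1)c1cc2cnccc2[nH]1`: 82%
compound 2 `O=C(NCc1ccc(S(=O)(=O)c2ccccc2)cc1)c1nc2cnccc2[nH]1`: 73%
compound 3 `O=C(NCc1ccc(S(=O)(=O)c2ccccc2)cc1)c1cc(-c2cccnc2)no1`: 69%

In an ADME assay on microsomes from liver (Homo sapiens) for metabolic stability, read by LC-MS, with a stated time of 30 min, tested at 1 uM (a higher number here means that more of the compound is left, a lower number that less of the compound is left), compound 1 gives 82%, compound 2 gives 73% and compound 3 gives 69%. Compound 2 holds the second highest of the three numbers; the nearest is compound 3 and the furthest is compound 1, both gaps within the scatter. Within the data shown here, on these three numbers the series therefore shows no separation in this assay, and no step between two measured compounds that differ in one place has been recorded.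

Compound 4 `O=C(NCc1ccc(S(=O)(=O)c2ccccc2)cc1)c1nc2ccncc2s1` is to be measured next. Against compound 2 the change is a group of 9 heavy atoms (6 carbon, 2 nitrogen, 1 sulfur; one five-membered aromatic ring with 2 hetero atoms, one six-membered aromatic ring with 1 hetero atom) in place of a group of 9 heavy atoms (6 carbon, 3 nitrogen; one five-membered aromatic ring with 2 hetero atoms, one six-membered aromatic ring with 1 hetero atom), on a carbonyl carbon. Among the measured compounds shown here, with no recorded step as a guide, the expectation for this change is no step beyond the scatter, in either direction.

Compound 4 is estimated at 70%, with a range from 52% to 86%. The expected step from compound 2 to compound 4 is a number 3 percentage points lower from compound 2 to compound 4 (within the scatter).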

Compound 4, percent of the compound remaining: 68%
For compound 4 the middle estimate is 2 percentage points above the measured one, within the range that was stated.
By their numbers in this assay, from the lowest: compounds 4, 3, 2 and 1 (each within the scatter of the next, the first and the last beyond it).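

At the carbonyl carbon whose other neighbour is the amide-type nitrogen, the series now has its first step between two compounds that differ in one place: this assay records a number 5 percentage points lower from compound 2 to compound 4 (within the scatter) for this exchange. The group of 9 heavy atoms (6 carbon, 2 nitrogen, 1 sulfur), with 0 hydrogen-bond donors, can therefore stand in place of the group of 9 heavy atoms (6 carbon, 3 nitrogen), with 1 hydrogen-bond donor, without a step beyond the scatter at this position. No measurement is at hand that bears on the reading of this step.

The compounds shown carry only aromatic ring groups on this carbonyl carbon, so how an open-chain amine or a carboxylic acid there would read in this assay remains open. A single step also leaves open whether the same holds with other groups on the sulfonyl side of the molecule.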